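Aryl swaps at the shared core: compound 3

This account rests on a few compounds, and the source may have more. Where it says the series, first, only, none or still open, it means among the compounds named here.

Within the data shown here, in an assay for binding affinity to dual specificity mitogen-activated protein kinase kinase 4 (Homo sapiens), read by KINOMEscan, tested at 100 nM (on this read-out higher numbers stand for a weaker effect at the one concentration tested and lower numbers for a stronger effect), compound 2 `CCCS(=O)(=O)Nc1ccc(F)c(C(=O)c2n[nH]c3ncc(-c4ccc(OC)cc4Cl)cc23)c1F` gives 5.3%, the highest of the two numbers measured so far. Compound 1 `CCCS(=O)(=O)Nc1ccc(F)c(C(=O)c2n[nH]c3ncc(-c4cccc(N)c4)cc23)c1F` gives 1.6% in this assay. The step of a number 3.7 percentage points higher from compound 1 to compound 2 (within the scatter) lies within the scatter. Compound 3 `CCCS(=O)(=O)Nc1ccc(F)c(C(=O)c2n[nH]c3ncc(-c4ccc(C(=O)O)cc4)cc23)c1F` differs from compound 2 in one place: 4-carboxyphenyl in place of 2-chloro-4-methoxyphenyl on an aromatic carbon. Among the measured compounds shown here, the only measured step that bears on this, a change of the group at the same place, stayed within the scatter, so a step of a number 1.7 percentage points higher from compound 2 to compound 3 (within the scatter) is expected, none beyond the scatter. Compound 3 is therefore estimated at 7%, with a range from 1% to 35%.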

Compound 3, a percentage reported as activity, at one concentration (the size of the read-out at that concentration, not a potency): 0.1%
Compound 3: middle estimate off by 6.9 percentage points, on the high side; the measured number lies below the stated range.
By their numbers in this assay, from the lowest: compounds 3, 1 and 2 (each within the scatter of the next).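

At this aromatic carbon of the shared core, 4-carboxyphenyl, which brings a hydrogen-bond donor and a second oxygen, also leaves the read-out in this assay unchanged: the result shows a number 5.2 percentage points lower from compound 2 to compound 3 (within the scatter) and a number 1.5 percentage points lower from compound 1 to compound 3 (within the scatter). All three aryl groups therefore sit within the scatter of one another, so this position shows no order among them. No evidence at hand accounts for this tolerance. Going by these compounds, whether a non-aromatic group such as a piperidine, or a simple methyl, would move the number beyond the scatter remains open.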